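A Chloro for Hydroxy Swap on an Inactive Series

This account rests on a few compounds, and the source may have more. Where it says the series, first, only, none or still open, it means among the compounds named here.

Compound 1 `CC1=CC[C@H](C(C)(C)N=C=S)CC1` is the isothiocyanate parent of this small set. In a functional assay on NCI/ADR-RES cells (Homo sapiens) for inhibition, read by sulforhodamine B assay, with a stated time of 48 h (on this read-out lower numbers stand for stronger inhibition of growth and higher numbers for weaker inhibition of growth), compound 1 gives only a limit of the assay, > 100000 nM. Compound 2 `CC1=CC[C@H](C(C)(C)NC(=S)N/N=C/c2ccc(O)cc2)CC1` carries a hydroxy group on its aromatic ring. In this assay compound 2 also reaches only the assay limit, > 100000 nM. Compound 3 `CC1=CC[C@H](C(C)(C)NC(=S)N/N=C/c2ccc(F)cc2)CC1` is the fluoro analogue. For compound 3 this assay again reports only a limit, > 100000 nM. The step that the two limits leave unreadable from compound 2 to compound 3 is thus not readable in size or direction, as both of its ends sit at the limit of > 100000 nM in this assay, at which 3 of the 3 values shown sit.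

Compound 4 `CC1=CC[C@H](C(C)(C)NC(=S)N/N=C/c2ccc(Cl)cc2)CC1` differs from compound 2 by chloro in place of hydroxy on an aromatic carbon. Going by the values given here, the only measured step at this position is a step that the two limits leave unreadable from compound 2 to compound 3, and it shows no movement that can be sized; nothing in the data tells whether a halogen in place of hydroxy shifts growth inhibition beyond the scatter. Compound 4 is therefore expected to stay at the limit as well, with an estimated step that the limit leaves unreadable from compound 2 to compound 4. For compound 4 the estimated value in this assay is 150000 nM, within a range from 60000 nM to 500000 nM.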

Compound 4, concentration for total growth inhibition: 97400 nM
Compound 4: middle estimate off by 1.5-fold (0.19 log units), on the high side; low and high end bracket the measured number.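

Going by these compounds alone, with chloro on the ring, compound 4 is the first member of this set to give a measured number rather than a limit in this assay (97400 nM). That gives a first, bounded reading for chloro in place of hydroxy (an at least 1.0-fold lower number from compound 2 to compound 4 (0.01 log units; that floor lies within the scatter)) and for chloro in place of fluoro (an at least 1.0-fold lower number from compound 3 to compound 4 (0.01 log units; that floor lies within the scatter)). Both floors lie within the usual scatter, so no gain in growth inhibition can be claimed for chloro, and most of the set still rests at one ceiling: the limit of > 100000 nM in this assay, at which 3 of the 4 values shown sit.

Still open, on these data alone, is whether bromo, methoxy or an amine at this place on the ring would move the number clearly beyond the scatter. Also open, as far as these compounds go, is how far compound 2 and compound 3 truly lie from compound 4, since each of those two is known only as a limit.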